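The source may hold more compounds than are shown below. What is called first, only, known or untested is meant among the compounds shown, and "the series" means these compounds.

Series so far, measured in a functional assay on MCF7 cells (Homo sapiens) for cytotoxicity, read by sulforhodamine B assay, with a stated time of 48 h; on this read-out lower numbers stand for stronger inhibition and higher numbers for weaker inhibition:

- compound 1 `COc1ccc(/C=C/C(=O)c2cccc(Br)c2)cc1OC` gives "not determined" (no result reported)
- compound 2 `COc1ccc(/C=C/C(=O)c2cccc(-c3cccc(F)c3)c2)cc1O` gives "not determined" (no result reported)
- compound 3 `COc1ccc(/C=C/C(=O)c2cccc(-c3cccc(F)c3)c2)cc1` gives 3080 nM

Among the compounds with values here, compound 3 at 3080 nM is the only number. Within the data shown here, compound 1 and compound 2 returned no result, so compound 3 cannot yet be ranked against anything, and no step between measured compounds is available to serve as a guide.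

The next compound is compound 4 `COc1ccc(/C=C/C(=O)c2cccc(-c3cccc(F)c3)c2)cc1OC`, which differs from compound 3 in one place. Methoxy stands in place of hydrogen on an aromatic carbon, ortho to a methoxy group and meta to a large group methoxy in place of hydrogen on an aromatic carbon and the rest of the structure is unchanged.

Among the measured compounds shown here, with no measured step to draw on, the expectation in this assay rests on compound 3 at 3080 nM and on the small size of this change. Going by these compounds, no step beyond the usual scatter is expected, and the direction remains open, with only a slight lean toward stronger inhibition. The estimated step of a 1.2-fold lower number from compound 3 to compound 4 (0.09 log units; within the scatter) is expected to stay that small. For compound 4 the expected value is 2500 nM with an estimated range from 700 nM to 9000 nM as the wide margin for a series with a single number.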

Compound 4, half-maximal inhibitory concentration: 4620 nM
For compound 4 the middle estimate is 1.8-fold (0.27 log units) below the measured one; low and high end bracket the measured number.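

In this assay, methoxy in place of hydrogen on an aromatic carbon, ortho to a methoxy group, gives a 1.5-fold higher number from compound 3 to compound 4 (0.18 log units; within the scatter). Within the data shown here, this is the only step between measured compounds, and it gives the first direct reading at this position: adding this group here leaves compound 3 and compound 4 unseparated by the read-out, so the series so far shows no sensitivity to this one change. No measurement of any property of these compounds bears on this result, so the step stays a plain observation without an explanation.

Still open, going by these compounds, is how this position responds to a group other than methoxy, such as an amine or a longer chain like ethoxy, since a single step within the scatter cannot show whether it would respond the same way to those. Also open, on these data alone, is the effect of hydroxy at the same position, as compound 2 carries that group but gives "not determined" (no result reported), so its comparison with compound 4 cannot be read.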